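This account rests on a few compounds, and the source may have more. Where it says the series, first, only, none or still open, it means among the compounds named here.

Compound 1 `CC(=O)Nc1c(C)c(C(OC(C)(C)C)C(=O)O)c(-c2ccc(C)c(C)c2)c(C)c1-c1ccc(C)c(C)c1` is the starting point. In an ADME assay on MT4 cells (Homo sapiens) for cytotoxicity, read by MTT assay, with a stated time of 4 days (on this read-out higher numbers stand for lower toxicity in this test and lower numbers for higher toxicity in this test), compound 1 gives 19000 nM, the lowest of the three numbers recorded, though within the scatter of both companions. Within the data shown here, compound 2 `Cc1ccc(-c2c(C)c(-c3ccc(Cl)cc3)c(C(OC(C)(C)C)C(=O)O)c(C)c2NS(C)(=O)=O)cc1C` gives 26000 nM and compound 3 `Cc1ccc(-c2c(C)c(-c3ccc4c(c3)CCO4)c(C(OC(C)(C)C)C(=O)O)c(C)c2NS(C)(=O)=O)cc1C` gives 38000 nM in this assay; the one step between them, a 1.5-fold higher number from compound 2 to compound 3 (0.16 log units; within the scatter), concerns a different part of the molecule. Compound 4 `Cc1ccc(-c2c(C)c(-c3ccc(C)c(C)c3)c(C(OC(C)(C)C)C(=O)O)c(C)c2NS(=O)(=O)C2CC2)cc1C` differs from compound 1 by cyclopropylsulfonyl in place of acetyl on a nitrogen on an aromatic ring. Among the measured compounds shown here, no measured step covers this change, and the numbers of compound 1 and compound 2 lie close together. Compound 4 is therefore expected to give 22000 nM, between 10000 nM and 48000 nM, with the expected step of a 1.2-fold higher number from compound 1 to compound 4 (0.06 log units; within the scatter) remaining inside the scatter.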

Compound 4, half-maximal cytotoxic concentration: 11000 nM
For compound 4 the middle estimate is 2.0-fold (0.30 log units) above the measured one; low and high end bracket the measured number.
By their numbers in this assay, from the lowest: compounds 4, 1, 2 and 3 (each within the scatter of the next, the first and the last beyond it).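

In this assay, among these compounds, cyclopropylsulfonyl in place of acetyl on a nitrogen on an aromatic ring gives a 1.7-fold lower number from compound 1 to compound 4 (0.24 log units; within the scatter), the only measured step at this position. The step lies within the scatter, so this read-out does not separate compound 1 from compound 4, even though the entering group has more heavy atoms and brings a three-membered ring. Nothing available here bears on the reason for this result. Going by these compounds, it remains open whether a free amine or a longer chain such as butylsulfonyl on this nitrogen would also stay within the scatter of compound 1. On these data alone, it is also open whether the same change would give a similar step on the core of compound 3.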